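The compounds below may be only part of what the source reports. "The series", "measured", "known", "first", "only" and "open" are said of these compounds alone.

Three compounds share one core, differing only in the group on a saturated chain carbon bound to an amine nitrogen in a ring. Compound 1 `CCN1CCN(CCC(=O)Nc2nc3c(C)cccc3s2)CC1` gives 543 nM in an assay on membranes from brain for displacement of a labelled ligand from Sigma non-opioid intracellular receptor 1 (Cavia porcellus), read by scintillation counting, with a stated time of 120 min; a higher number here means a weaker inhibitor, a lower number a stronger inhibitor. Compound 2 `CCCCN1CCN(CCC(=O)Nc2nc3c(C)cccc3s2)CC1` gives 204 nM, a step of a 2.7-fold lower number from compound 1 to compound 2 (0.43 log units; beyond the scatter). Compound 3 `Cc1cccc2sc(NC(=O)CCN3CCN(CC4CCCCC4)CC3)nc12` gives 35 nM, the lowest of the three numbers, with a 5.8-fold lower number from compound 2 to compound 3 (0.77 log units; beyond the scatter) and a 16-fold lower number from compound 1 to compound 3 (1.19 log units; beyond the scatter).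

Compound 4 `Cc1cccc2sc(NC(=O)CCN3CCN(CCN(C(C)C)C(C)C)CC3)nc12` is not yet measured. The change from compound 3 is (diisopropylamino)methyl in place of cyclohexyl on a saturated chain carbon bound to an amine nitrogen in a ring. The two steps that touch this position, from the methyl of compound 1 and the propyl of compound 2 to the cyclohexyl of compound 3, both lowered the number; leaving the cyclohexyl for a branched acyclic group with one hydrogen-bond acceptor removes the feature that accompanied those gains. A step back toward the numbers of compound 2 or compound 1 is therefore expected, beyond the scatter but of modest size.

Compound 4 is estimated at 150 nM, within 40 nM to 600 nM, an expected step of a 4.3-fold higher number from compound 3 to compound 4 (0.63 log units; beyond the scatter).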

Compound 4, inhibition constant: 809 nM
The estimate for compound 4 lay 5.4-fold (0.73 log units) below the measured number; the whole stated range lies below it.
By their numbers in this assay, from the lowest: compound 3; then compound 2; then compounds 1 and 4 (each within the scatter of the next).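

In this assay, replacing cyclohexylmethyl with 2-(diisopropylamino)ethyl cancels the whole gain seen at this position, with a 23-fold higher number from compound 3 to compound 4 (1.36 log units; beyond the scatter), so a group with more heavy atoms does not by itself keep the number low. The new group also falls behind the shorter chain of compound 2, with a 4.0-fold higher number from compound 2 to compound 4 (0.60 log units; beyond the scatter), and gains nothing over compound 1, with a 1.5-fold higher number from compound 1 to compound 4 (0.17 log units; within the scatter). No measurement here bears on why this happens.

In this change the carbocycle leaves and an amine nitrogen enters together, so the compounds shown cannot assign the loss to either one. A 2-cyclohexylethyl group, or a 2-(piperidin-1-yl)ethyl group that keeps a ring alongside the nitrogen, would separate the two.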